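The compounds below may be only part of what the source reports. "The series", "measured", "known", "first", "only" and "open" are said of these compounds alone.

Three members of the series carry numbers in a functional assay on HEK293 cells for antagonist activity at Voltage-dependent L-type calcium channel subunit alpha-1C (Oryctolagus cuniculus), read by FLIPR; a lower number here means a stronger inhibitor, a higher number a weaker inhibitor. Compound 1 `CCOC(=O)C1=C(C)NC(COC(=O)c2ccccc2)=C(C(=O)OCC)C1c1cccc([N+](=O)[O-])c1` gives 210 nM there, compound 2 `CCOC(=O)C1=C(C)NC(C)=C(C(=O)OCCOC)C1c1cccc([N+](=O)[O-])c1` gives 16 nM, and compound 3 `COC(=O)C1=C(C)NC(C)=C(C(=O)OCc2ccccc2)C1c1cccc([N+](=O)[O-])c1` gives 25 nM. Among these three, compound 3 holds the second highest number: the gap to compound 2 lies within the scatter, so no order between those two can be read, while the gap to compound 1, which has the higher number, lies beyond the scatter. Compound 4 `COC(=O)C1=C(C)NC(C)=C(C(=O)OCCCCc2ccc(OC)cc2)C1c1cccc([N+](=O)[O-])c1` has not been measured. It differs from compound 3 in one place: 3-(4-methoxyphenyl)propyl in place of phenyl on a saturated chain carbon bound to an oxygen next to a carbonyl group. For the measured compounds named here, no measured pair isolates this change, and compound 1 and compound 2, which also vary at the saturated chain carbon bound to an oxygen next to a carbonyl group, differ from compound 3 in other ways too, so only their values can be compared. For compound 4 the expected step is a 1.4-fold higher number from compound 3 to compound 4 (0.15 log units; within the scatter), that is, small and leaning toward a higher number, likely not clearly beyond the scatter. Compound 4 is estimated at 35 nM, with a range from 9 nM to 140 nM.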

Compound 4, half-maximal inhibitory concentration: 17 nM
Beside the measured number, compound 4's estimate is 2.1-fold (0.31 log units) above it, within the range that was stated.
By their numbers in this assay, from the lowest: compounds 2, 4 and 3 (each within the scatter of the next); then compound 1.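

For the compounds shown here, this is the first matched pair at the saturated chain carbon bound to an oxygen next to a carbonyl group: in this assay, 3-(4-methoxyphenyl)propyl in place of phenyl gives a 1.5-fold lower number from compound 3 to compound 4 (0.17 log units; within the scatter). The entering group has 11 heavy atoms against 6 and adds one hydrogen-bond acceptor, yet the pair shows no readable difference, so for this pair the position accommodates the larger group. No measurement available here accounts for this result.

The pair changes the chain and the methoxy group together, so 3-phenylpropyl would be needed to separate the two. On these data alone, whether the position also accepts an amine or a carboxylic acid in place of 3-(4-methoxyphenyl)propyl remains open.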